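Swapping Acetoxy for Phenylsulfonylamino on the Saturated Ring

The source may hold more compounds than are shown below. What is called first, only, known or untested is meant among the compounds shown, and "the series" means these compounds.

Compound 3 `CC(=O)OC1CCC(CN2CCN(c3cc(=O)c4cc(C(F)(F)F)cc([N+](=O)[O-])c4s3)CC2)CC1` was tested in an ADME assay on Vero cells (Chlorocebus sabaeus) for cytotoxicity, read by MTT assay, with a stated time of 48 h; on this read-out higher numbers stand for weaker inhibition and lower numbers for stronger inhibition. In this assay compound 3 gives > 64 ug/mL, which is a limit of the assay rather than a number. Compound 1 `CCCC(=O)OC1CCC(CN2CCN(c3cc(=O)c4cc(C(F)(F)F)cc([N+](=O)[O-])c4s3)CC2)CC1` gives > 64 ug/mL, also a limit. Compound 2 `O=c1cc(N2CCN(CC3CCC(OS(=O)(=O)c4cccnc4)CC3)CC2)sc2c([N+](=O)[O-])cc(C(F)(F)F)cc12` gives > 64 ug/mL, again a limit. The steps a step that the two limits leave unreadable from compound 1 to compound 2, a step that the two limits leave unreadable from compound 1 to compound 3 and a step that the two limits leave unreadable from compound 2 to compound 3 therefore cannot be read, and the limit of > 64 ug/mL in this assay, at which 3 of the 3 values shown sit, sums up the picture. Compound 4 `O=c1cc(N2CCN(CC3CCC(NS(=O)(=O)c4ccccc4)CC3)CC2)sc2c([N+](=O)[O-])cc(C(F)(F)F)cc12` differs from compound 3 by (phenylsulfonyl)amino in place of acetoxy on a saturated ring carbon. Among the compounds with values here, no measured step can guide this change, yet every measured relative sits at the limit. Compound 4 is therefore expected to give 80 ug/mL, between 40 ug/mL and 200 ug/mL. This expected step, a step that the limit leaves unreadable from compound 3 to compound 4, would be none beyond the scatter, most likely reported once more only as a limit.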

Compound 4, half-maximal inhibitory concentration: > 64 ug/mL
Compound 4 was reported as a limit; the forecaster's own chance of this, stated with the estimate: 85%; the middle value lies beyond the limit too.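

Compound 4 also sits at a limit, so its steps from compound 1, compound 2 and compound 3 cannot be read in this assay: the limit of > 64 ug/mL in this assay, at which 4 of the 4 values shown sit.

The compounds shown leave open what number each would actually give, and whether any of these groups on the saturated ring changes it.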